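A few compounds are considered here, and "the series" means these few. Any claim that something is new, unique, unknown or untested is made for them only; others in the source may bear on it.

Measured in a functional assay on HCT-116 cells (Homo sapiens) for antiproliferative activity, read by MTT assay, with a stated time of 48 h; a higher number here means a weaker inhibitor, a lower number a stronger inhibitor:
- Compound 1 `CCCCCCCC(CCO)n1cnc2c(NC)ncnc21`: 12500 nM
- Compound 2 `CCCCCCCC(CCO)n1cnc2c(N(C)C)ncnc21`: > 50000 nM (a limit)

Compound 2 shows no number in this assay. Its > 50000 nM is a limit of the assay and nothing more, so compound 2 stands at the limit of > 50000 nM in this assay, at which 1 of the 2 values shown sits.

Compound 3 `CCCCCCCCCCCC(CCO)n1cnc2c(N(C)C)ncnc21` keeps the dimethylated nitrogen of compound 2 and differs from it only in the chain: butyl in place of hydrogen on a saturated chain carbon, eight bonds along the chain from an aromatic nitrogen. In words, butyl takes the place of hydrogen on a saturated chain carbon, eight bonds along the chain from an aromatic nitrogen.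

Within the data shown here, only one measured step is available, an at least 4.0-fold higher number from compound 1 to compound 2 (0.60 log units; beyond the scatter). It is methyl in place of hydrogen on a nitrogen on an aromatic ring, so it lies at a different place and gives no size for a change in the chain. Among the measured compounds shown here, no measured pair varies the chain, and the starting point is only a limit. No step beyond the scatter is therefore expected in this assay, in either direction, though the uncertainty is wide. The expected change is a number no higher from compound 2 to compound 3 (the limit leaves the size open). Compound 3 is estimated at 50000 nM, with an expected range from 15000 nM to 120000 nM.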

Compound 3, half-maximal inhibitory concentration: 12000 nM
For compound 3 the middle estimate is 4.2-fold (0.62 log units) above the measured one, and the stated range ends above it.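

Among these compounds, the chain, which no earlier pair had varied, proves to matter in this assay: butyl in place of hydrogen on a saturated chain carbon, eight bonds along the chain from an aromatic nitrogen, gives an at least 4.1-fold lower number from compound 2 to compound 3 (0.61 log units; beyond the scatter). Compound 3 keeps the dimethylated nitrogen and still gives a measured number, 12000 nM, so that nitrogen alone does not take a compound of this series out of the measurable range. The size of this step stays open on one side, as the starting value of compound 2 is a limit and not a number: the limit of > 50000 nM in this assay, at which 1 of the 3 values shown sits.

The compounds shown do not tell whether the effect of the added butyl would continue with a still longer chain, or whether the same change would act in the same way on the singly methylated nitrogen of compound 1. They also leave open how the shared core would fare with an amine or a carboxylic acid on the chain, since every compound here carries only a plain alkyl chain and the same hydroxyl-bearing arm.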